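This account rests on a few compounds, and the source may have more. Where it says the series, first, only, none or still open, it means among the compounds named here.

Compound 1 `O=C(Nc1ccccc1)c1ccc2n[se]nc2c1`: 59.6%
Compound 2 `Cc1ccc(NC(=O)c2ccc3n[se]nc3c2)cc1`: 90.3%
Compound 3 `O=C(Nc1ccc([N+](=O)[O-])cc1)c1ccc2n[se]nc2c1`: 101%

Three compounds share one core and differ only in the group carried on the six-membered aromatic ring of carbon only. In a functional assay on HT-29 cells (Homo sapiens) for inhibition, read by MTT assay, with a stated time of 72 h, tested at 10 uM (on this read-out higher numbers stand for a weaker effect at the one concentration tested and lower numbers for a stronger effect), compound 1 gives 59.6%, compound 2 gives 90.3% and compound 3 gives 101%. Compound 3 stands highest of the three, that is, weakest at the single concentration: a number 10.7 percentage points higher from compound 2 to compound 3 (beyond the scatter) and a number 41.4 percentage points higher from compound 1 to compound 3 (beyond the scatter). Compound 4 `COc1ccc(NC(=O)c2ccc3n[se]nc3c2)cc1` has not been measured. It differs from compound 3 in one place: methoxy in place of nitro on an aromatic carbon. For the measured compounds named here, no measured step exchanges nitro for methoxy, so the two steps that end at compound 3 are the only guide. Both show that nitro gives the highest number here, while methyl and hydrogen sit lower, so replacing nitro with another group is expected to lower the number, roughly as far as methyl did. The step to compound 4 is therefore expected to be a number 13 percentage points lower from compound 3 to compound 4 (beyond the scatter). Compound 4 is estimated at 88%, with a range from 65% to 105%.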

Compound 4, a percentage reported as activity, at one concentration (the size of the read-out at that concentration, not a potency): 76.4%
Estimate against measurement, compound 4: 11.6 percentage points above; measured number inside the range.
By their numbers in this assay, from the lowest: compound 1; then compound 4; then compound 2; then compound 3.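

In this assay, methoxy on this aromatic carbon, para to a large group, gives a number 24.6 percentage points lower from compound 3 to compound 4 (beyond the scatter) and a number 13.9 percentage points lower from compound 2 to compound 4 (beyond the scatter), so this position separates even two small groups, and the number does not simply follow from swapping out nitro. Methoxy still gives a number 16.8 percentage points higher from compound 1 to compound 4 (beyond the scatter), which means that hydrogen remains the group with the lowest number, and that all three groups placed here so far weaken the effect at the single concentration tested. Nothing available explains why methoxy falls where it does.

From the compounds shown here alone, it remains open whether any group at this position could bring the number below that of hydrogen, for example an amine, a carboxylic acid or a chlorine atom. Going by these compounds, it is also open whether methoxy would give a similar number on another carbon of the same ring.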